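Fluoro substitution on the aryl ring of compound 1

The compounds below may be only part of what the source reports. "The series", "measured", "known", "first", "only" and "open" are said of these compounds alone.

Compound 1 `c1ccc(-c2c3c(nn2C2CC2)CCNCC3)cc1` is the reference point for this step. In an assay on HEK293 cells for displacement of a labelled ligand from 5-hydroxytryptamine receptor 7 (Rattus norvegicus), read by radioligand binding (a lower number here means a stronger inhibitor, a higher number a weaker inhibitor), compound 1 gives 20 nM, the only single number shown for it; one further entry carries no single number. Within the data shown here, compound 2 `CC(C)n1nc2c(c1-c1ccc(F)cc1)CCNCC2` differs from compound 1 in two places rather than one, so no single step connects the two; in this assay compound 2 gives 7.94 nM; 8 nM (2 entries), and its repeated entries the several entries of compound 2 in this assay, 7.94 nM; 8 nM (2 entries) agree closely with each other. Compound 3 `Fc1ccc(-c2c3c(nn2C2CC2)CCNCC3)cc1` is the compound still to be measured in this assay. It differs from compound 1 by fluoro in place of hydrogen on an aromatic carbon. Among the measured compounds shown here, no step between measured compounds is at hand for this particular change. The change is expected to move this assay only slightly, if at all, in the direction of stronger binding, within or barely beyond the usual scatter; the expected step from compound 1 to compound 3 is a 1.7-fold lower number from compound 1 to compound 3 (0.22 log units; within the scatter). Compound 3 is therefore estimated at 12 nM, with a range from 5 nM to 30 nM.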

Compound 3, inhibition constant: 100 nM
For compound 3 the middle estimate is 8.3-fold (0.92 log units) below the measured one; measured number outside the range, above it.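

In this assay, this position proves sensitive to a single added atom: fluoro in place of hydrogen on the aromatic carbon, para to a large group, gives a 5.0-fold higher number from compound 1 to compound 3 (0.70 log units; beyond the scatter), so the change weakens binding rather than leaving it unchanged. The same fluoro does not rule out a low number in this series, since with isopropyl in place of the cyclopropyl of compound 3, compound 2, which also carries fluoro, gives 7.94 nM; 8 nM (2 entries), while compound 3 gives 100 nM. The only direct check on reproducibility in this assay comes from another compound, and its repeats sit close together, though this says nothing about why the step occurs: the several entries of compound 2 in this assay, 7.94 nM; 8 nM (2 entries)

The compounds shown leave open whether the loss belongs to fluoro specifically or to any group at this place, as a chloro, methoxy or nitrile group there would show. They also leave open whether fluoro costs the same with isopropyl as with cyclopropyl, since the partner of compound 2 with hydrogen on that aromatic carbon is not among them.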